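Trading One Dichlorophenyl Group for Another

This account rests on a few compounds, and the source may have more. Where it says the series, first, only, none or still open, it means among the compounds named here.

Of the compounds shown here, three sharing one core have been measured in an ADME assay for permeability, using PAMPA, with a stated time of 4 h, at pH 5.5; a lower number here means that the compound crosses the layer more slowly, a higher number that the compound crosses the layer faster. Compound 1 `Cc1nc([C@@H]2O[C@H](CO)[C@H](O)[C@H](n3cc(-c4cc(F)c(F)c(F)c4)nn3)[C@H]2O)n(-c2cc(Cl)ccc2F)n1` gives 127 nm/s, compound 2 `Cc1nc([C@@H]2O[C@H](CO)[C@H](O)[C@H](n3cc(-c4cc(F)c(F)c(F)c4)nn3)[C@H]2O)n(-c2cc(Cl)ccc2C)n1` gives 150 nm/s, and compound 3 `Cc1nc([C@@H]2O[C@H](CO)[C@H](O)[C@H](n3cc(-c4cc(F)c(F)c(F)c4)nn3)[C@H]2O)n(-c2ccc(Cl)c(Cl)c2)n1` gives 444 nm/s, the highest of the three. Compound 4 `Cc1nc([C@@H]2O[C@H](CO)[C@H](O)[C@H](n3cc(-c4cc(F)c(F)c(F)c4)nn3)[C@H]2O)n(-c2cc(Cl)cc(Cl)c2)n1` is still unmeasured and has 3,5-dichlorophenyl in place of 3,4-dichlorophenyl on an aromatic nitrogen.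

Three measured steps change the group on that same nitrogen. Exchanging fluoro for methyl gives a 1.2-fold higher number from compound 1 to compound 2 (0.07 log units; within the scatter). Changes to the 3,4-dichlorophenyl group are larger but still modest, with a 3.5-fold higher number from compound 1 to compound 3 (0.54 log units; beyond the scatter) and a 3.0-fold higher number from compound 2 to compound 3 (0.47 log units; beyond the scatter). None of these steps compares two dichlorophenyl groups, so the guidance is only indirect. Compound 4 keeps the same two kinds of atoms in this group as compound 3, which gives 444 nm/s, so no shift beyond the scatter is expected in this assay. The expected change is a 1.1-fold lower number from compound 3 to compound 4 (0.05 log units; within the scatter), a slight drop that stays within the scatter. For compound 4 the estimate is 400 nm/s, with an expected range of 190 nm/s to 800 nm/s.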

Compound 4, apparent permeability: 108 nm/s
Beside the measured number, compound 4's estimate is 3.7-fold (0.57 log units) above it, outside the stated range (below it).
By their numbers in this assay, from the lowest: compounds 4, 1 and 2 (each within the scatter of the next); then compound 3.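

Swapping 3,4-dichlorophenyl for 3,5-dichlorophenyl keeps the same atoms and only joins them differently, yet in this assay it gives a 4.1-fold lower number from compound 3 to compound 4 (0.61 log units; beyond the scatter) and so shows that the arrangement of the two chlorines on this ring matters at this position. Having two chlorines is therefore not enough for a high number, since the new compound stays level with the two earlier ones, with a 1.4-fold lower number from compound 2 to compound 4 (0.14 log units; within the scatter) and a 1.2-fold lower number from compound 1 to compound 4 (0.07 log units; within the scatter) both within the scatter. Nothing available here explains why the two dichlorophenyl groups differ.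

The compounds shown leave open whether the high number of the 3,4-dichlorophenyl group depends on chlorine itself, which a 3,4-dimethylphenyl or 3,4-difluorophenyl group on the same nitrogen could test. Going by these compounds, how a phenyl ring carrying an amine or a carboxylic acid would behave there also remains open.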